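From Propoxy to Cyclohexylmethoxy on a Shared Core

The source may report more compounds than this note shows. Statements on the series, on what has been measured and on what is new or still open speak of the compounds shown alone.

The measured compounds:
compound 1, `O=C1CSc2cc(OCc3ccccc3)ccc2N1` — 71 nM
compound 2, `CCCOc1ccc2c(c1)SCC(=O)N2` — 2870 nM

Both were tested in an assay on isolated protein for inhibition of Amine oxidase [flavin-containing] B (Homo sapiens), read by fluorescence and spectrophotometry, with a stated time of 20 min; a lower number here means a stronger inhibitor, a higher number a weaker inhibitor. Among the two numbers known, compound 2 stands at the higher one, with compound 1 as its only neighbour; the step of a 40-fold higher number from compound 1 to compound 2 (1.61 log units; beyond the scatter) is the sole measured step here, and it is a large one.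

Compound 3, `O=C1CSc2cc(OCC3CCCCC3)ccc2N1`, is not yet measured. It differs from compound 2 in one place: cyclohexyl in place of ethyl on a saturated chain carbon bound to an oxygen on an aromatic ring. Going by the values given here, the only step that bears on this change is the one from compound 1 to compound 2, where a six-membered aromatic ring in place of ethyl on the same saturated chain carbon came with a much lower number. Since the group entering in compound 3 is again a six-membered ring of six carbon atoms, the account expects the step from compound 2 to compound 3 in this assay to run the other way, toward a clearly lower number, on the order of a 19-fold lower number from compound 2 to compound 3 (1.28 log units; beyond the scatter), though not necessarily as far as the benzyl case.

For compound 3 the estimated value in this assay is 150 nM, within a range of 40 nM to 600 nM.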

Compound 3, half-maximal inhibitory concentration: 24 nM
Estimate against measurement, compound 3: 6.3-fold (0.80 log units) above; measured number below the stated range.
By their numbers in this assay, from the lowest: compound 3; then compound 1; then compound 2.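

Compound 1 had shown only that a phenyl at this place, on a saturated chain carbon bound to an oxygen on an aromatic ring, gives a far lower number than ethyl; compound 3 shows that an aromatic ring is not needed for that gain. In this assay the change to cyclohexyl gives a 120-fold lower number from compound 2 to compound 3 (2.08 log units; beyond the scatter) and so exceeds the drop seen with phenyl. The two rings are also separated from each other, with a 3.0-fold lower number from compound 1 to compound 3 (0.47 log units; beyond the scatter) for cyclohexyl in place of phenyl: this step is modest but beyond the scatter, and among these three compounds the saturated ring gives the lowest number.

The three groups do not tell whether the ring itself matters or whether a straight hexyl chain would serve as well, nor how a smaller cyclopentyl ring or a piperidine ring carrying an amine would fare at this place. The compounds shown also come with no measurement that would explain why cyclohexyl and phenyl differ so strongly from ethyl or from each other.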